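The source may report more compounds than this note shows. Statements on the series, on what has been measured and on what is new or still open speak of the compounds shown alone.

Going by the values given here, only two compounds sharing the same core have been measured so far, and they differ only in the group on a carbonyl carbon. In a functional assay on HCT-15 cells (Homo sapiens) for inhibition, read by colorimetric assay and sulforhodamine B assay, with a stated time of 48 h (a higher number here means a weaker inhibitor of growth, a lower number a stronger inhibitor of growth), compound 1 `CCCCCCCCCCCC[C@@H](O)[C@H]1CC[C@H]([C@H](O)CCCCCCCCCCNC(=O)c2ccco2)O1`, which carries furan-2-yl there, gives 100000 nM. Among the compounds with values here, compound 2 `CCCCCCCCCCCC[C@@H](O)[C@H]1CC[C@H]([C@H](O)CCCCCCCCCCNC(=O)c2cncs2)O1`, which carries 1,3-thiazol-5-yl, gives 100000 nM in this assay, so it stands level with compound 1, its only measured neighbour.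

The next compound, compound 3 `CCCCCCCCCCCC[C@@H](O)[C@H]1CC[C@H]([C@H](O)CCCCCCCCCCNC(=O)c2ccnn2C)O1`, has 1-methyl-1H-pyrazol-5-yl in place of 1,3-thiazol-5-yl on a carbonyl carbon. The group that leaves and the group that enters are both five-membered aromatic rings. Within the data shown here, the one measured step that bears on this swap is no change at the digits printed from compound 1 to compound 2 (within the scatter), also an exchange of one ring for another at this place. Among the measured compounds shown here, that step stayed within the scatter, but a single step is thin evidence, and no measured compound carries the added methyl. The expected result in this assay is no shift beyond the scatter, as no change at the digits printed from compound 2 to compound 3 (within the scatter). The estimate for compound 3 is 100000 nM, with an expected range of 45000 nM to 120000 nM.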

Compound 3, concentration for 50% growth inhibition: 100000 nM
The estimate for compound 3 equals the measured number at the digits printed; the range from low to high includes it.
By their numbers in this assay, from the lowest: compounds 1, 2 and 3 (each within the scatter of the next).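

Going by these compounds alone, replacing 1,3-thiazol-5-yl with 1-methyl-1H-pyrazol-5-yl on the carbonyl carbon gives no change at the digits printed from compound 2 to compound 3 (within the scatter) in this assay and brings a ring carrying a methyl group to this place for the first time, with 6 heavy atoms in place of 5 and no sulfur. Set against furan-2-yl, the same entering ring gives no change at the digits printed from compound 1 to compound 3 (within the scatter) in this assay and closes the comparison, so all three five-membered aromatic rings shown at this place read alike in this assay. Nothing measured here gives a reason for this sameness.

From the compounds shown here alone, what a phenyl ring, a pyridine ring or a plain methyl group would do on this carbonyl carbon stays open, as the three compounds cover only five-membered aromatic rings there. They also leave open whether changes elsewhere, such as a shorter chain or the loss of a hydroxyl group from the shared core, would move the reading at all, since all three compounds carry these parts unchanged.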